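This account rests on a few compounds, and the source may have more. Where it says the series, first, only, none or still open, it means among the compounds named here.

Measured compounds:
- compound 1 `N[C@]1(C(=O)O)[C@H]2[C@@H](C[C@H]1OCc1cccc(C(F)(F)F)c1)[C@]2(F)C(=O)O`: 5.72 nM
- compound 2 `N#Cc1cccc(CO[C@@H]2C[C@@H]3[C@H]([C@]2(N)C(=O)O)[C@@]3(F)C(=O)O)c1`: 2.94 nM
- compound 3 `N[C@]1(C(=O)O)[C@H]2[C@@H](C[C@H]1OCc1ccc(-c3ccccc3)cc1)[C@]2(F)C(=O)O`: 25.6 nM

All three share the same core and differ only in the aromatic group hung from the ether. In an assay on CHO cells for binding affinity to metabotropic glutamate receptor 2 (Rattus norvegicus) (on this read-out lower numbers stand for stronger inhibition and higher numbers for weaker inhibition), compound 2 gives 2.94 nM, the lowest of the three numbers. Compound 1 gives 5.72 nM, and the step of a 1.9-fold lower number from compound 1 to compound 2 (0.29 log units; within the scatter) is too small to tell the two apart. Compound 3 gives 25.6 nM, a clearly higher number, beyond the usual scatter.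

Compound 4 `N[C@]1(C(=O)O)[C@H]2[C@@H](C[C@H]1OCc1c(Cl)cccc1Cl)[C@]2(F)C(=O)O` is the next step from compound 2: 2,6-dichlorophenyl in place of 3-cyanophenyl on a saturated chain carbon bound to an oxygen on a saturated carbon. Within the data shown here, no measured step covers this change. Among the measured compounds shown here, the only measured step, a 1.9-fold lower number from compound 1 to compound 2 (0.29 log units; within the scatter), swaps one group for another on the aromatic ring and stays within the scatter, while compound 3 shows that a different aromatic group can raise the number considerably. Compound 4 keeps a single six-membered ring but with two chlorines and no hydrogen-bond acceptor, so the expectation is a moderate rise in the number, though with wide uncertainty. Compound 4 is therefore estimated at 8 nM, with a range from 2 nM to 35 nM. This estimate means a step of a 2.7-fold higher number from compound 2 to compound 4 (0.43 log units; beyond the scatter), expected to go toward weaker binding.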

Compound 4, inhibition constant: 4.3 nM
For compound 4 the middle estimate is 1.9-fold (0.27 log units) above the measured one; the measured number falls inside the stated range.
By their numbers in this assay, from the lowest: compounds 2, 4 and 1 (each within the scatter of the next); then compound 3.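

In this assay, putting 2,6-dichlorophenyl in place of 3-cyanophenyl on the saturated chain carbon bound to the ether oxygen gives a 1.5-fold higher number from compound 2 to compound 4 (0.17 log units; within the scatter) and so leaves the two compounds indistinguishable on this read-out. This is the first step shown that replaces the whole aromatic group rather than one substituent on it, and it shows that, for this pair, a group with no hydrogen-bond acceptor and two chlorines can read the same as a group with a nitrile and one hydrogen-bond acceptor. Nothing measured here bears on why these two different groups give such similar numbers.

The compounds shown leave open whether both chlorines are needed, which a plain phenyl or a 2-chlorophenyl group would test, and whether the ring must be aromatic at all, which a cyclohexyl group would test. They also leave open whether the number would stay in this range with an amine or a carboxylic acid on the ring.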